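From 2-hydroxyethyl to 1-hydroxyethyl on a triple-bonded carbon

The compounds below may be only part of what the source reports. "The series", "measured", "known", "first", "only" and "open" are said of these compounds alone.

Compound 1 `COc1ccc(C#Cc2cc(Cl)cn3c([N+](=O)[O-])c(CS(=O)(=O)c4ccccc4)nc23)cc1`: > 3900 nM (a limit)
Compound 2 `O=[N+]([O-])c1c(CS(=O)(=O)c2ccccc2)nc2c(C#CCCO)cc(Cl)cn12`: > 125000 nM (a limit)

In an ADME assay on HepG2 cells (Homo sapiens) for cytotoxicity, read by MTT assay, with a stated time of 72 h (on this read-out higher numbers stand for lower toxicity in this test and lower numbers for higher toxicity in this test), compound 2 stands only at a limit, > 125000 nM. Compound 1 likewise gives only a limit, > 3900 nM. Among the measured compounds shown here, the one measured step, 2-hydroxyethyl in place of 4-methoxyphenyl on a triple-bonded carbon, is a step that the two limits leave unreadable from compound 1 to compound 2.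

Compound 3 `CC(O)C#Cc1cc(Cl)cn2c([N+](=O)[O-])c(CS(=O)(=O)c3ccccc3)nc12` has the same atoms as compound 2, joined differently: 1-hydroxyethyl in place of 2-hydroxyethyl on a triple-bonded carbon. In words, 1-hydroxyethyl stands in place of 2-hydroxyethyl on a triple-bonded carbon. No readable size carries over to this change, so no step beyond the scatter is expected in this assay, and a further limit is likely. The expected step is a number no higher from compound 2 to compound 3 (the limit leaves the size open). For compound 3 the estimate is 125000 nM, with an expected range of 60000 nM to 250000 nM.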

Compound 3, half-maximal cytotoxic concentration: 44200 nM
Compound 3: the middle estimate sits 2.8-fold (0.45 log units) above what was measured, and the stated range ends above it.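

In this assay, compound 3 alone of the three gives a number and not a limit, so this place on a triple-bonded carbon now has a readable result. Replacing 2-hydroxyethyl with 1-hydroxyethyl gives an at least 2.8-fold lower number from compound 2 to compound 3 (0.45 log units; beyond the scatter) and shows that the read-out responds to how the same atoms are joined, with none added or lost. That size is only a minimum because compound 2 stands at a limit: the limit of > 125000 nM in this assay, at which 1 of the 3 values shown sits.

The steps that start from compound 1 cannot be read. From the compounds shown here alone, it remains open whether an amine in place of the hydroxyl of 1-hydroxyethyl, or a longer chain carrying the hydroxyl, would move the number in this assay further.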